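Aryl amide series: removing the aromatic chloro

A few compounds are considered here, and "the series" means these few. Any claim that something is new, unique, unknown or untested is made for them only; others in the source may bear on it.

Compound 1 `O=C(C1CC1)N(O)c1ccc(Cl)cc1`, compound 2 `O=C(CCC1CCCC1)N(O)c1ccc(Cl)cc1` and compound 3 `O=C(CC1CCCCC1)N(O)c1ccc(Cl)cc1` share one core and differ only in the acyl group. In a functional assay on MIA PaCa-2 cells (Homo sapiens) for inhibition (on this read-out higher numbers stand for weaker inhibition and lower numbers for stronger inhibition), compound 1 reaches only a limit, > 100000 nM. In this assay compound 2 gives 7000 nM, and compound 3 gives 8000 nM. For the measured compounds named here, the one step between measured compounds, a 1.1-fold higher number from compound 2 to compound 3 (0.06 log units; within the scatter), lies on the acyl chain. Compound 3 thus stands highest of the two numbers, with compound 2 nearest and within the scatter; the remaining value is a limit.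

Compound 4 `O=C(CC1CCCCC1)N(O)c1ccccc1` differs from compound 3 by hydrogen in place of chloro on an aromatic carbon, para to a large group. Going by the values given here, no measured step touches this ring position: the only step available, a 1.1-fold higher number from compound 2 to compound 3 (0.06 log units; within the scatter), changes the acyl side and says nothing about the chloro. No direction can therefore be taken from the measured steps, and the expectation in this assay is a step of uncertain sign, probably modest in size. For compound 4 the expected step is a 1.5-fold higher number from compound 3 to compound 4 (0.18 log units; within the scatter). Compound 4 is accordingly estimated at 12000 nM, with a range from 4000 nM to 40000 nM.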

Compound 4, half-maximal inhibitory concentration: 40000 nM
Beside the measured number, compound 4's estimate is 3.3-fold (0.52 log units) below it; the range from low to high includes it.
By their numbers in this assay, from the lowest: compounds 2 and 3 (each within the scatter of the next); then compound 4. At a limit, above all of these: compound 1.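

Hydrogen in place of chloro on the aromatic carbon para to a large group gives a 5.0-fold higher number from compound 3 to compound 4 (0.70 log units; beyond the scatter) in this assay, so this ring position, which no earlier step touched, does affect the read-out, and the compound without chloro shows weaker inhibition. Unlike the only earlier step, a 1.1-fold higher number from compound 2 to compound 3 (0.06 log units; within the scatter), on the acyl side, this change lies beyond the scatter. The step is read between two numbers, and only compound 1 sits at a limit: the limit of > 100000 nM in this assay, at which 1 of the 4 values shown sits.

The pair cannot show whether chloro is specifically favoured here or whether a fluoro, bromo, methyl or methoxy group in the same place would serve equally well. It also leaves open whether the same change gives a similar step with the acyl group of compound 2.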